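A few compounds are considered here, and "the series" means these few. Any claim that something is new, unique, unknown or untested is made for them only; others in the source may bear on it.

Measured compounds:
- compound 1 `Cc1cc(Nc2cc(-c3ccccc3)[nH]n2)n2nc(SCCc3ccccc3)nc2n1`: 37400 nM
- compound 2 `Cc1cc(Nc2ccn(Cc3cccc4ccccc34)n2)n2nc(SCc3ccc(Br)cc3)nc2n1`: 30000 nM

Both compounds have been run in an ADME assay on GES1 cells (Homo sapiens) for inhibition, read by MTT assay, with a stated time of 72 h; on this read-out lower numbers stand for stronger inhibition and higher numbers for weaker inhibition. In this assay compound 1 gives 37400 nM, and compound 2 gives 30000 nM. Of the two numbers that of compound 1 is the larger, but the gap to compound 2 lies within the scatter, so no order between the two can be read from these values. Both sit in a weak range on this read-out.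

Compound 3 `Cc1cc(Nc2cc(-c3ccccc3)[nH]n2)n2ncnc2n1` is not yet measured. It differs from compound 1 in one place: hydrogen in place of phenethylsulfanyl on an aromatic carbon. The shared core of compound 1 and compound 3 is otherwise unchanged.

For the measured compounds named here, no step between measured compounds is available to calibrate this change. Given that compound 1 is already weak in this assay and that the change strips a sizeable group from the core, the expectation is a step of modest size toward a higher number, or none beyond the scatter; the expected step of a 1.5-fold higher number from compound 1 to compound 3 (0.17 log units; within the scatter) reflects this. Compound 3 is estimated at 55000 nM, with a range from 20000 nM to 150000 nM.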

Compound 3, half-maximal inhibitory concentration: > 50000 nM
Compound 3 ended at the assay's limit; the forecaster's own chance of this, stated with the estimate: 30%; the middle value lies beyond the limit too.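

In this assay compound 3 gives > 50000 nM as a limit of the assay and not as a number. Hydrogen in place of phenethylsulfanyl, on the aromatic carbon between two ring nitrogen atoms, gives an at least 1.3-fold higher number from compound 1 to compound 3 (0.12 log units; that floor lies within the scatter) and so provides the first reading of this position: taking the whole group away does not yield a lower number, and the shared core with hydrogen at this place stays weak on this read-out. The true size of the step cannot be fixed because compound 3 rests at the limit, and the printed floor alone does not separate the pair beyond the scatter: the limit of > 50000 nM in this assay, at which 1 of the 3 values shown sits.

The compounds shown leave open whether a shorter group on the same carbon, such as methylsulfanyl, or an amine there would give a number close to that of compound 1 or would also reach the limit. Compound 2 differs from compound 1 and compound 3 in more than one place, so it adds nothing on this position, and the effect of the group on the sulfur remains unresolved within the series.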